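This account rests on a few compounds, and the source may have more. Where it says the series, first, only, none or still open, it means among the compounds named here.

Measured so far in an assay on isolated protein for binding affinity to adenosine receptor A1 (Bos taurus); on this read-out higher numbers stand for weaker inhibition and lower numbers for stronger inhibition:
compound 1 `COc1ccc(C(=O)Nc2nc(-c3ccccc3)nc3c2nnn3Cc2ccccc2F)cc1` gives 21900000 nM
compound 2 `CNc1nc(-c2ccccc2)nc2c1nnn2Cc1ccccc1Cl` gives 191000000 nM

Compound 1 holds the lower of the two numbers in this assay; compound 2 sits at a higher number, and the gap between them lies beyond the usual scatter. Both numbers stand far up the scale.

Compound 3 `CCCNc1nc(-c2ccccc2)nc2c1nnn2Cc1ccccc1F` has not yet been measured in this assay. It differs from compound 1 at one place: propyl in place of (4-methoxyphenyl)carbonyl on a nitrogen on an aromatic ring. Among the measured compounds shown here, no pair of measured compounds carries this same change, so no measured step can be read across directly. The only other point of reference is compound 2, which gives 191000000 nM and so sits higher than compound 1. On that basis compound 3 is expected to move toward a higher number, with a step of a 3.7-fold higher number from compound 1 to compound 3 (0.56 log units; beyond the scatter) that is expected to lie beyond the scatter. The estimate for compound 3 is 80000000 nM, expected within a range from 20000000 nM to 300000000 nM.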

Compound 3, inhibition constant: 3200000 nM
For compound 3 the middle estimate is 25-fold (1.40 log units) above the measured one; measured number below the stated range.
By their numbers in this assay, from the lowest: compound 3; then compound 1; then compound 2.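

At the nitrogen on the aromatic ring, the (4-methoxyphenyl)carbonyl group is not required for the binding seen so far in this assay: exchanging it for propyl gives a 6.8-fold lower number from compound 1 to compound 3 (0.84 log units; beyond the scatter). The smaller group, with no ring and no hydrogen-bond acceptors, therefore gives the lower number of this pair, although compound 3 at 3200000 nM still stands far up the scale. Nothing available explains this step.

This single pair cannot separate the loss of the aromatic ring from the loss of the carbonyl; benzyl or acetyl on the same nitrogen would pull the two apart. As far as these compounds go, whether a longer chain such as butyl, or the unsubstituted amine, would move the number further from that of compound 3 remains open.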